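The compounds below may be only part of what the source reports. "The series", "measured", "known", "first", "only" and "open" are said of these compounds alone.

Values in a physicochemical assay for lipophilicity, using the shake flask method, in phosphate buffer, measured as octanol-water partition, at pH 7.4; on this read-out higher numbers stand for higher lipophilicity and lower numbers for lower lipophilicity:
Compound 1 `CCC[C@@H](c1ccc(C(=O)O)c(Oc2cccc(Cl)c2)c1OC)N1CCC[C@H](n2cc(C)c(=O)[nH]c2=O)C1`: 0.13
Compound 2 `Cc1cn([C@H]2CCCN([C@@H](CC(C)C)c3ccc(C(=O)O)c(Oc4cccc(Cl)c4)c3F)C2)c(=O)[nH]c1=O`: 0.57
Compound 3 `CCC[C@@H](c1ccc(C(=O)O)c(Oc2cccc(Cl)c2)c1F)N1CCC[C@H](n2cc(C)c(=O)[nH]c2=O)C1`: 0.51

Compound 1 has the lowest number of the three, and the other two lie beyond the scatter from it. Next to be measured is compound 4 `COc1c(CN2CCC[C@H](n3cc(C)c(=O)[nH]c3=O)C2)ccc(C(=O)O)c1Oc1cccc(Cl)c1`, which differs from compound 1 as follows: hydrogen in place of propyl on a saturated chain carbon bound to an amine nitrogen in a ring and an aromatic carbon. In words, this is hydrogen in place of propyl on a saturated chain carbon bound to an amine nitrogen in a ring and an aromatic carbon.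

The closest measured change is a number 0.06 log units lower from compound 2 to compound 3 (within the scatter), with hydrogen in place of methyl on a saturated chain carbon bound to two saturated chain carbons. It sits at a different place and stays within the scatter. The other step, a number 0.38 log units higher from compound 1 to compound 3 (beyond the scatter), is fluoro in place of methoxy on an aromatic carbon, so it bears only on the size of movement seen in this series. For the measured compounds named here, no measured step removes a whole chain, so the size remains uncertain. A modest drop is expected, and the estimated change is a number 0.43 log units lower from compound 1 to compound 4 (beyond the scatter). The estimate for compound 4 is -0.3, with an expected range from -0.8 to 0.2.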

Compound 4, distribution coefficient: -0.77
Estimate against measurement, compound 4: 0.47 log units above, within the range that was stated.
By their numbers in this assay, from the lowest: compound 4; then compound 1; then compounds 3 and 2 (each within the scatter of the next).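

In this assay, for the compounds shown here, taking the propyl off the saturated chain carbon bound to an amine nitrogen in a ring and an aromatic carbon gives a number 0.90 log units lower from compound 1 to compound 4 (beyond the scatter), the first measured change at this place and the first that removes a whole chain. This step is larger than a number 0.38 log units higher from compound 1 to compound 3 (beyond the scatter), and it stands apart from the loss of a methyl on a saturated chain carbon bound to two saturated chain carbons, a number 0.06 log units lower from compound 2 to compound 3 (within the scatter), so the read-out does respond to what sits at this place.

From the compounds shown here alone, whether a methyl or an ethyl here would give part of this step or nearly all of it remains open, as does the reading for a longer chain. Also open, going by these compounds, is whether the same removal gives a step of this size on the fluoro core of compound 3.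

No measurement on hand accounts for the size of this step.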